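A Smaller Halogen on the Core of Compound 1

The source may report more compounds than this note shows. Statements on the series, on what has been measured and on what is new or still open speak of the compounds shown alone.

Compound 1, `FC(F)(F)c1ncnc2c1ncn2C1COc2ccccc2CO1`: 1250 nM
Compound 2, `c1ccc(Sc2ncnc3ncn(C4CNc5ccccc5CO4)c23)cc1`: 48900 nM
Compound 3, `COC(CN(c1ccccc1CO)S(=O)(=O)c1ccc([N+](=O)[O-])cc1)n1c(=O)cc[nH]c1=O`: 55200 nM

In a functional assay on MCF7 cells (Homo sapiens) for antiproliferative activity (a higher number here means a weaker inhibitor, a lower number a stronger inhibitor), compound 1 gives the lowest of the three numbers. Compound 2 comes nearest, and compound 3 lies furthest away; both of those gaps are beyond the scatter. Among the measured compounds shown here, none of the three measured compounds differs from another in a single place, so no measured step exists from which the size of a change at this position could be read.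

Compound 4, `Clc1ncnc2c1ncn2C1COc2ccccc2CO1`, differs from compound 1 by chloro in place of trifluoromethyl on an aromatic carbon. With nothing measured that bears on this exchange, the step is expected to be small, a 1.6-fold higher number from compound 1 to compound 4 (0.20 log units; within the scatter), in the direction of a slightly weaker inhibitor. Compound 4 is estimated at 2000 nM, within a range from 500 nM to 8000 nM.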

Compound 4, half-maximal inhibitory concentration: 1250 nM
Estimate against measurement, compound 4: 1.6-fold (0.20 log units) above, and the stated range covers the measured number.
By their numbers in this assay, from the lowest: compounds 1 and 4 (each within the scatter of the next); then compounds 2 and 3 (each within the scatter of the next).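

In this assay, among the compounds shown here, the exchange of trifluoromethyl for chloro on an aromatic carbon gives no change at the digits printed from compound 1 to compound 4 (within the scatter) and supplies the first measured step at this position. This aromatic carbon of the core of compound 1 therefore accepts chloro in place of trifluoromethyl with no change beyond the scatter. Nothing measured here explains this outcome.

As far as these compounds go, whether an amine or a methoxy group on this aromatic carbon would hold the number as chloro does remains open. So does whether the same exchange would give a similar step on a different core.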